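Phenyl on the chain carbon of compound 2

A few compounds are considered here, and "the series" means these few. Any claim that something is new, unique, unknown or untested is made for them only; others in the source may bear on it.

Values measured in a physicochemical assay for solubility, measured as kinetic solubility, at pH 2 (a lower number here means a less soluble compound, a higher number a more soluble compound), are as follows.
- compound 1 `CCC(CC)C(/C=C1\OC(=O)NC1=O)c1ccc(-c2ccc3cccc(F)c3c2)[nH]c1=O` gives 3680 nM
- compound 2 `O=C1NC(=O)/C(=C/C(c2ccc(-c3ccc4cccc(F)c4c3)[nH]c2=O)C2CC2)O1` gives 3850 nM
- compound 3 `CC(C)C(c1ccc(-c2ccc3cccc(F)c3c2)[nH]c1=O)C1C(=O)NC(=O)N1C` gives 13600 nM

Compound 2 sits level with compound 1 within the scatter, while compound 3 shows a higher number, beyond the scatter from compound 2. Compound 4 `O=C1NC(=O)/C(=C/C(c2ccccc2)c2ccc(-c3ccc4cccc(F)c4c3)[nH]c2=O)O1` is not yet measured. The change from compound 2 is phenyl in place of cyclopropyl on a saturated chain carbon bound to an aromatic carbon and a double-bonded chain carbon and it puts phenyl in place of cyclopropyl on a saturated chain carbon bound to an aromatic carbon and a double-bonded chain carbon.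

Among the measured compounds shown here, one measured step bears on this: a 1.0-fold higher number from compound 1 to compound 2 (0.02 log units; within the scatter) with cyclopropyl in place of pentan-3-yl at the same place. For the measured compounds named here, compound 3 has no single-place step to compound 2 and gives no guide here. Going by the values given here, no measured compound carries phenyl at this place, so the range is kept wide. Starting from compound 2 at 3850 nM and with that one step as the guide, no step beyond the scatter is expected in this assay for this change. The estimated step is a 1.2-fold lower number from compound 2 to compound 4 (0.08 log units; within the scatter) on this reading. Compound 4 is expected at 3200 nM with an estimated range from 1400 nM to 7500 nM in repeat measurements.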

Compound 4, solubility: 15400 nM
For compound 4 the middle estimate is 4.8-fold (0.68 log units) below the measured one; the whole stated range lies below it.
By their numbers in this assay, from the lowest: compounds 1 and 2 (each within the scatter of the next); then compounds 3 and 4 (each within the scatter of the next).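

In this assay the saturated chain carbon bound to an aromatic carbon and a double-bonded chain carbon turns out to respond to the group it carries: the earlier change gave only a 1.0-fold higher number from compound 1 to compound 2 (0.02 log units; within the scatter), whereas phenyl gives a 4.0-fold higher number from compound 2 to compound 4 (0.60 log units; beyond the scatter) and a 4.2-fold higher number from compound 1 to compound 4 (0.62 log units; beyond the scatter) and both steps lie beyond the scatter. Among the three groups at this place, phenyl alone stands apart, while cyclopropyl and pentan-3-yl remain level with each other. Nothing at hand gives a measured reason for this step.

The compounds shown do not separate the aromatic ring from the six-membered ring size, which cyclohexyl at this place would do, and pyridyl would extend the comparison to a nitrogen-bearing aromatic ring. From the compounds shown here alone, it also remains open whether phenyl gives a similar step on the core of compound 3.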